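The source may hold more compounds than are shown below. What is called first, only, known or untested is meant among the compounds shown, and "the series" means these compounds.

Compound 1 `CCCCN(c1nc2c(C(=O)O)cccc2o1)[C@H](C)c1ccc(-c2ccccc2-c2nnn[nH]2)cc1` — 17 nM
Compound 2 `CCCCN(c1nc2c(-c3nccn3C)cccc2o1)[C@H](C)c1ccc(-c2ccccc2-c2nnn[nH]2)cc1` — 10 nM
Compound 3 `CCCCN(c1nc2c(C(=O)NS(C)(=O)=O)cccc2o1)[C@H](C)c1ccc(-c2ccccc2-c2nnn[nH]2)cc1` — 14 nM

All three numbers come from a functional assay on CAL1 cells for inhibition of chemerin-like receptor 1 (Homo sapiens), with a stated time of 45 min; a lower number here means a stronger inhibitor, a higher number a weaker inhibitor. Among them compound 3 stands second highest, with compound 1 its nearest neighbour and compound 2 the furthest, every gap within the scatter. Compound 4 `CCCCN(c1nc2c(-c3ccccn3)cccc2o1)[C@H](C)c1ccc(-c2ccccc2-c2nnn[nH]2)cc1` differs from compound 3 in one place: pyridin-2-yl in place of (methylsulfonyl)carbamoyl on an aromatic carbon. The step that bears most on this change is a 1.4-fold higher number from compound 2 to compound 3 (0.15 log units; within the scatter), where (methylsulfonyl)carbamoyl replaced 1-methyl-1H-imidazol-2-yl; a 1.7-fold lower number from compound 1 to compound 2 (0.23 log units; within the scatter) adds a second view of that position. Neither step left the scatter, so in this assay no step beyond the scatter is expected here. Compound 4 is therefore estimated at 12 nM, with a range from 5 nM to 30 nM, which means an expected 1.2-fold lower number from compound 3 to compound 4 (0.07 log units; within the scatter).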

Compound 4, half-maximal inhibitory concentration: 110 nM
For compound 4 the middle estimate is 9.2-fold (0.96 log units) below the measured one; the measured number lies above the stated range.
By their numbers in this assay, from the lowest: compounds 2, 3 and 1 (each within the scatter of the next); then compound 4.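

In this assay this position turns out not to accept every group: pyridin-2-yl gives a 7.9-fold higher number from compound 3 to compound 4 (0.90 log units; beyond the scatter) and a 6.5-fold higher number from compound 1 to compound 4 (0.81 log units; beyond the scatter) and also an 11-fold higher number from compound 2 to compound 4 (1.04 log units; beyond the scatter), all beyond the scatter, whereas the three earlier groups stayed within it. The last of these steps swaps one aromatic ring for another, so an aromatic ring here does not by itself keep the number low. Nothing measured explains this loss. On these data alone, whether a phenyl ring or a plain carboxamide at this position would stay close to compound 4 or to compounds 1, 2 and 3 remains open.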